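The compounds below may be only part of what the source reports. "The series", "measured", "known", "first", "only" and "open" are said of these compounds alone.

Measured compounds in an ADME assay on HepG2 cells (Homo sapiens) for cytotoxicity, read by CellTiter-Glo and resazurin assay, with a stated time of 72 h; a lower number here means that less compound is needed, a higher number that more compound is needed for the effect:

Compound 1, `CC(C)N(Cc1cccc(OCCCCCC(=O)O)c1)C(=O)c1ccc(-c2cccc3ccccc23)cc1`, gives > 26000 nM, a limit of the assay.
Compound 2, `CC(C)N(Cc1cccc(OCCCCCC(=O)O)c1)C(=O)c1ccc(-c2c[nH]c3ccccc23)cc1`, gives > 26000 nM, a limit of the assay.
Compound 3, `CCOC(=O)CCCCCOc1cccc(CN(C(=O)c2ccc(-c3cccc4ccccc34)cc2)C(C)C)c1`, gives > 26000 nM, a limit of the assay.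

Compound 3 thus stands at the limit of > 26000 nM in this assay, at which 3 of the 3 values shown sit, and no number within the measured range is known for it. The two steps that have been measured both start from compound 1: a step that the two limits leave unreadable from compound 1 to compound 2 and a step that the two limits leave unreadable from compound 1 to compound 3. Neither step can be read, since both compounds of each pair sit at the same limit.

Compound 4, `CCOC(=O)CCCCCOc1cccc(CN(C(=O)c2ccc(-c3cccc(O)c3)cc2)C(C)C)c1`, differs from compound 3 in one place: 3-hydroxyphenyl in place of naphthalen-1-yl on an aromatic carbon. For the measured compounds named here, of the measured steps, the one from compound 1 to compound 2 is closest in kind, as it also removes naphthalen-1-yl. Yet a step that the two limits leave unreadable from compound 1 to compound 2 gives no size and no direction. Going by the values given here, no measured step therefore shows a change in this assay beyond the scatter, and nothing known here points compound 4 away from the limit.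

Compound 4 is expected to give about 30000 nM in this assay, within a range from 12000 nM to 100000 nM, and the expected step that the limit leaves unreadable from compound 3 to compound 4 is most likely to remain unreadable, with the value again reported only as a limit.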

Compound 4, half-maximal effective concentration: > 26000 nM
Compound 4 was reported as a limit; the forecaster's own chance of this, stated with the estimate: 80%; the middle value lies beyond the limit too.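

In this assay, compound 3 and compound 4 are each reported only as a limit, so the change from naphthalen-1-yl to 3-hydroxyphenyl cannot be read in size or direction. The compounds shown leave open at what concentration any of them would reach the half-maximal effect, and whether any single change would shift it.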